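Cytotoxicity of a benzothiazole series: from methoxy to chloro

The source may hold more compounds than are shown below. What is called first, only, known or untested is meant among the compounds shown, and "the series" means these compounds.

Compound 1 `Fc1ccc2nc(Nn3c(-c4ccc(Cl)cc4)nnc3-c3cccnc3)sc2c1` gives 92.9 ug/mL in an ADME assay on MT4 cells (Homo sapiens) for cytotoxicity, read by MTT assay, with a stated time of 5 days; a higher number here means that more compound is tolerated, a lower number that less compound is tolerated.
Compound 2 `Cc1ccc2nc(Nn3c(-c4ccc(Cl)cc4)nnc3-c3cccnc3)sc2c1` gives 75.5 ug/mL in this assay.
Compound 3 `COc1ccc2nc(Nn3c(-c4ccc(Cl)cc4)nnc3-c3cccnc3)sc2c1` gives 66.9 ug/mL in this assay.

Compound 3 has the lowest of the three numbers in this assay, but all three sit within the scatter of one another: a 1.4-fold lower number from compound 1 to compound 3 (0.14 log units; within the scatter) and a 1.1-fold lower number from compound 2 to compound 3 (0.05 log units; within the scatter), and likewise a 1.2-fold lower number from compound 1 to compound 2 (0.09 log units; within the scatter). The three measured steps therefore show that exchanging fluoro, methyl or methoxy at this position of the shared core leaves the half-maximal cytotoxic concentration essentially unchanged.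

Compound 4 `Clc1ccc(-c2nnc(-c3cccnc3)n2Nc2nc3ccc(Cl)cc3s2)cc1` differs from compound 3 by chloro in place of methoxy on an aromatic carbon. Within the data shown here, no measured step covers chloro at this position, so the expectation rests only on the three substituents already examined, none of which moved the number beyond the scatter. On that basis compound 4 is expected to show a 1.0-fold higher number from compound 3 to compound 4 (0.02 log units; within the scatter) in this assay, with no step beyond the scatter anticipated. The estimate for compound 4 is 70 ug/mL, within a range of 40 ug/mL to 120 ug/mL.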

Compound 4, half-maximal cytotoxic concentration: 54.3 ug/mL
Estimate against measurement, compound 4: 1.3-fold (0.11 log units) above, within the range that was stated.
By their numbers in this assay, from the lowest: compounds 4, 3, 2 and 1 (each within the scatter of the next).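

With chloro, four groups have now been read at this position of the shared core. In this assay, the change to chloro gives a 1.2-fold lower number from compound 3 to compound 4 (0.09 log units; within the scatter) against methoxy and a 1.4-fold lower number from compound 2 to compound 4 (0.14 log units; within the scatter) against methyl, while against fluoro it gives a 1.7-fold lower number from compound 1 to compound 4 (0.23 log units; within the scatter) as the widest gap in the set. Even this widest pair stays within the scatter, so adding a second halogen to the series does not separate any of the four compounds, and nothing measured here offers an explanation for how closely their numbers lie.

The groups shown at this position carry no net charge, so it remains open whether an amine or a carboxylic acid there would keep the number in the same range. Going by these compounds, how a longer chain would read at this position also remains open, as does the effect of any change elsewhere on the shared core.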